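This account rests on a few compounds, and the source may have more. Where it says the series, first, only, none or still open, it means among the compounds named here.

Working notes on the series built on the core of compound 1 `COc1cc(Cl)cc(-c2nn(-c3cccc(NC(=O)Nc4cccc(C(F)(F)F)c4)c3)cc2-c2ccncc2)c1`. In a functional assay on UACC-257 cells (Homo sapiens) for inhibition, read by sulforhodamine B assay, with a stated time of 48 h, tested at 0.01 uM (a lower number here means a stronger effect, a higher number a weaker effect of the compound at the concentration tested), compound 1 gives 90%. Compound 2 `COc1cc(Cl)cc(-c2nn(-c3cccc(NC(=O)Nc4ccc(Cl)c(Cl)c4)c3)cc2-c2ccncc2)c1` differs by a 3,4-dichlorophenyl in place of 3-(trifluoromethyl)phenyl on an amide-type nitrogen, and in this assay compound 2 gives 96%. Going by the values given here, the one measured step, a number 6 percentage points higher from compound 1 to compound 2 (within the scatter), is within the scatter, so compound 1 stands level with compound 2 on this read-out and no order between the two can be drawn.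

Compound 3 `COc1cc(Cl)cc(-c2nn(-c3cccc(NC(=O)Nc4cc(C(F)(F)F)cc(C(F)(F)F)c4)c3)cc2-c2ccncc2)c1` is not yet measured. Against compound 1 it shows (trifluoromethyl in place of hydrogen on an aromatic carbon). Among the compounds with values here, no measured step probes this exact change; the only step at hand, a number 6 percentage points higher from compound 1 to compound 2 (within the scatter), exchanged the whole group on the amide-type nitrogen and stayed within the scatter, giving no sign that variation on this ring moves the number. The step is therefore expected to be a number 1 percentage points higher from compound 1 to compound 3 (within the scatter), within the scatter in either direction. For compound 3 the estimated value in this assay is 91%, with a range from 80% to 101%.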

Compound 3, a percentage reported as activity, at one concentration (the size of the read-out at that concentration, not a potency): 96%
For compound 3 the middle estimate is 5 percentage points below the measured one, within the range that was stated.
By their numbers in this assay, from the lowest: compounds 1, 2 and 3 (each within the scatter of the next).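

Trifluoromethyl in place of hydrogen on an aromatic carbon, at the place meta to a large group and meta to a trifluoromethyl group, is the first probe of this single position, and in this assay it gives a number 6 percentage points higher from compound 1 to compound 3 (within the scatter) on this read-out. Where the earlier step exchanged the whole group on the amide-type nitrogen, this one keeps that group and adds only 4 heavy atoms at one carbon, and it too stays within the scatter, so at this concentration the position takes a trifluoromethyl with no readable difference from hydrogen. Nothing at hand bears on why this result comes out as it does.

Whether a group of another kind on this same aromatic carbon, such as an amine or a carboxylic acid, would separate from compound 1 remains open, since hydrogen and trifluoromethyl are the only two groups shown here. A single low concentration also leaves open whether compound 1 and compound 3 would stay level at higher concentrations, where a full concentration response could be read.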